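The source may hold more compounds than are shown below. What is called first, only, known or untested is meant among the compounds shown, and "the series" means these compounds.

This series shares a naphthyloxy-acetohydrazone core and was tested in an ADME assay on HEL cells (Homo sapiens) for cytotoxicity; a higher number here means that more compound is tolerated, a lower number that less compound is tolerated. Compound 1 `COc1cc(/C=N/NC(=O)COc2cccc3ccccc23)cc(OC)c1OC` carries three methoxy groups on its benzylidene ring; in this assay compound 1 gives >= 20 ug/mL, which is a limit of the assay and not a measured number, (the limit of >= 20 ug/mL in this assay, at which 1 of the 3 values shown sits). Compound 2 `O=C(COc1cccc2ccccc12)N/N=C/c1c(O)ccc2ccccc12`, with a hydroxynaphthalene on the hydrazone side, gives 4 ug/mL in this assay, meaning cells tolerate it least among the measured compounds. Compound 3 `O=C(COc1cccc2ccccc12)N/N=C/c1ccccc1[N+](=O)[O-]`, which bears a nitro group on the benzylidene ring, gives 20 ug/mL in this assay; this is the higher of the two numbers, and the gap to compound 2 lies beyond the scatter.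

Compound 4 `O=C(COc1cccc2ccccc12)N/N=C/c1ccccc1` has not yet been measured. Compared with compound 3, the difference is hydrogen in place of nitro on an aromatic carbon. With only a hydrogen in place of the nitro group and no other change, no large shift in this assay is expected; the step from compound 3 to compound 4 is estimated at no change at the digits printed from compound 3 to compound 4 (within the scatter), which stays within the scatter. Compound 4 is therefore expected to give about 20 ug/mL in this assay, with a likely range from 8 ug/mL to 50 ug/mL, and it may also come back only as a limit.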

Compound 4, minimum cytotoxic concentration: 100 ug/mL
Compound 4: the middle estimate sits 5.0-fold (0.70 log units) below what was measured; measured number above the stated range.
By their numbers in this assay, from the lowest: compound 2; then compound 3; then compound 4.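

In this assay, going by these compounds alone, replacing the nitro group with hydrogen gives a 5.0-fold higher number from compound 3 to compound 4 (0.70 log units; beyond the scatter), and this pair provides the first comparison that differs in only one place. It shows that this position, on an aromatic carbon of the six-membered ring and ortho to a large group, is not indifferent to what it carries: with the rest of the molecule unchanged, more compound is tolerated with hydrogen there than with the nitro group. The data shown contain no measurement that accounts for the size of this step.

From the compounds shown here alone, whether the step belongs to the nitro group in particular or would appear with any group on this carbon remains open, and an amine or a chlorine atom at the same place would help separate those two readings. Going by these compounds, it is also open whether a nitro group on a different carbon of the ring would give a similar step, or whether the same change would matter on another core, as a single pair speaks for only one position in one setting.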